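This account rests on a few compounds, and the source may have more. Where it says the series, first, only, none or still open, it means among the compounds named here.

For the measured compounds named here, compound 3 `CC(C)c1onc(-c2c(Cl)cccc2Cl)c1COc1ccc(-c2nc3ccc(C(=O)O)cc3n2C(C)C)cc1` stands at the low end of the three numbers so far: in an assay on Huh-7 cells for agonist activity at Bile acid receptor (Homo sapiens), read by a luciferase reporter (a higher number here means that more compound is needed for the effect, a lower number that less compound is needed), compound 3 gives 3.39 nM. Compound 2 `CC(C)c1onc(-c2c(Cl)cccc2Cl)c1COc1ccc(-c2nc3ccc(C(=O)O)cc3n2CC(C)(C)C)cc1` gives 13 nM in this assay, and compound 1 `CC(C)c1onc(-c2c(Cl)cccc2Cl)c1COc1ccc(-c2nc3cc(C(=O)O)ccc3n2C)cc1` gives 25.8 nM. Going by the values given here, the one step that has been measured between neighbours is a 3.8-fold lower number from compound 2 to compound 3 (0.58 log units; beyond the scatter), the only guide to what a change of the group on the aromatic nitrogen does here.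

Compound 4 `CC(=O)N1CCC(n2c(-c3ccc(OCc4c(-c5c(Cl)cccc5Cl)noc4C(C)C)cc3)nc3ccc(C(=O)O)cc32)CC1` carries a different group at that same position: 1-acetylpiperidin-4-yl in place of isopropyl on an aromatic nitrogen. Among the compounds with values here, only the step from compound 2 to compound 3 bears on this change, and it went in the opposite sense, from a bulkier group to a smaller one. Since compound 4 brings in a larger group than compound 3, a shift back toward higher numbers is expected, though the new group is of another kind and the size of the shift is uncertain. The expected step is a 2.4-fold higher number from compound 3 to compound 4 (0.37 log units; beyond the scatter), a modest rise. Compound 4 is therefore estimated to give 8 nM, with a range from 2.5 nM to 30 nM.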

Compound 4, half-maximal effective concentration: 1430 nM
For compound 4 the middle estimate is 180-fold (2.25 log units) below the measured one; the measured number lies above the stated range.
By their numbers in this assay, from the lowest: compound 3; then compounds 2 and 1 (each within the scatter of the next); then compound 4.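

For the compounds shown here, the group on the aromatic nitrogen matters far more in this assay than the earlier compounds showed: 1-acetylpiperidin-4-yl gives a 420-fold higher number from compound 3 to compound 4 (2.63 log units; beyond the scatter), and measured against neopentyl it gives a 110-fold higher number from compound 2 to compound 4 (2.04 log units; beyond the scatter). Both steps are much larger than a 3.8-fold lower number from compound 2 to compound 3 (0.58 log units; beyond the scatter), so the change between the two small alkyl groups gave no measure of how far the number can move at this position. No evidence is available on why this group behaves so differently.

The new group differs from isopropyl at once in its heavy-atom count, its six-membered ring with a nitrogen, and its acetyl, so the compounds shown do not tell which of these goes with the rise. A plain cyclohexyl or a piperidin-4-yl with a free amine at this position would help to separate the ring from the acetyl.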